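Taking the trifluoromethyl off a weak growth inhibitor

The source may report more compounds than this note shows. Statements on the series, on what has been measured and on what is new or still open speak of the compounds shown alone.

In a functional assay on NCI-H23 cells (Homo sapiens) for inhibition, read by sulforhodamine B assay, with a stated time of 48 h (on this read-out higher numbers stand for weaker inhibition of growth and lower numbers for stronger inhibition of growth), compound 1 (`COc1cc(-c2nn(-c3cccc(NC(=O)c4cccc(C(F)(F)F)c4)c3)cc2-c2ccncc2)ccc1Cl`) gives 32500 nM as the higher of the two actual numbers here. Compound 2 (`COc1cc(-c2nn(-c3cccc(NC(=O)c4ccc(Cl)c(C(F)(F)F)c4)c3)cc2-c2ccncc2)ccc1Cl`) stands at > 32500 nM as a limit of the assay, not a number. Compound 3 (`COc1cc(-c2nn(-c3cccc(NC(=O)Nc4ccc(Cl)c(C(F)(F)F)c4)c3)cc2-c2ccncc2)ccc1Cl`) gives 8030 nM as the lower number. Among the compounds with values here, compound 4 (`COc1cc(-c2nn(-c3cccc(NC(=O)c4ccccc4)c3)cc2-c2ccncc2)ccc1Cl`) differs from compound 1 by hydrogen in place of trifluoromethyl on an aromatic carbon, and no measured step changes that group. The closest evidence is a number no lower from compound 1 to compound 2 (the limit leaves the size open) for chloro in place of hydrogen, its size left open by the limit. The modest 4.0-fold lower number from compound 1 to compound 3 (0.61 log units; beyond the scatter) lies at the carbonyl carbon, elsewhere in the molecule. So a 1.1-fold lower number from compound 1 to compound 4 (0.03 log units; within the scatter) is expected in this assay as a step within the scatter. For compound 4 the estimated value is 30000 nM and the expected range runs from 12000 nM up to 50000 nM at its top.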

Compound 4, concentration for total growth inhibition: > 100000 nM
Compound 4 ended at the assay's limit; the forecaster's own chance of this, stated with the estimate: 45%; middle value at least 3.3-fold (0.52 log units) from the limit.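

Compound 4 stands at a limit of the assay, not at a number: the limit of > 100000 nM in this assay, at which 1 of the 4 values shown sits.

Within the data shown here, at this position, hydrogen in place of trifluoromethyl gives an at least 3.0-fold higher number from compound 1 to compound 4 (0.48 log units; beyond the scatter) in this assay, so this group does count here, which no earlier step could show. The wider change at the carbonyl carbon gives an at least 12-fold higher number from compound 3 to compound 4 (1.09 log units; beyond the scatter) in the same assay, while the step between the two limits cannot be read.

From the compounds shown here alone, whether a methyl, a methoxy or a carboxylic acid at this position would keep the level of compound 1 stays open. Going by these compounds, how far compound 4 lies past its limit also stays open.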